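This account rests on a few compounds, and the source may have more. Where it says the series, first, only, none or still open, it means among the compounds named here.

Of the compounds shown here, three built on one shared core have so far been measured in an assay on isolated protein (Bos taurus) for inhibition of geranylgeranyl transferase type-1 subunit beta (Homo sapiens); on this read-out higher numbers stand for weaker inhibition and lower numbers for stronger inhibition. Compound 1 `Cn1cncc1C(OCc1ccc(C#N)c(-c2ccc(Cl)c(Cl)c2)n1)c1ccc(C#N)cc1` gives 1600 nM, compound 2 `Cn1cncc1C(OCc1ccc(C#N)nc1-c1cccc(Cl)c1)c1ccc(C#N)cc1` gives 1700 nM, and compound 3 `Cn1cncc1C(OCc1ccc(C#N)c(-c2ccc3ccccc3c2)n1)c1ccc(C#N)cc1` gives 2600 nM. Compound 2 stands second highest of these three numbers, nearest to compound 1 and furthest from compound 3, with both gaps within the scatter. Compound 4 `Cn1cncc1C(OCc1ccc(C#N)nc1-c1ccc2ccccc2c1)c1ccc(C#N)cc1` has not yet been measured; it differs from compound 2 in one place: naphthalen-2-yl in place of 3-chlorophenyl on an aromatic carbon. Among the compounds with values here, the one measured step that bears on this is a 1.6-fold higher number from compound 1 to compound 3 (0.21 log units; within the scatter), a closely similar exchange on a close relative. A step of comparable size, if any, toward a higher number is therefore expected. Compound 4 is expected to give 2700 nM, with a range from 1400 nM to 5200 nM. That estimate means a step of a 1.6-fold higher number from compound 2 to compound 4 (0.20 log units; within the scatter), which would lie within the scatter.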

Compound 4, half-maximal inhibitory concentration: 5500 nM
For compound 4 the middle estimate is 2.0-fold (0.31 log units) below the measured one, outside the stated range (above it).
By their numbers in this assay, from the lowest: compounds 1, 2 and 3 (each within the scatter of the next); then compound 4.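

In this assay, within the data shown here, naphthalen-2-yl in place of 3-chlorophenyl gives a 3.2-fold higher number from compound 2 to compound 4 (0.51 log units; beyond the scatter), the only step here beyond the scatter, so at this position, next to the ring nitrogen, this change weakens inhibition. The related exchange, a 1.6-fold higher number from compound 1 to compound 3 (0.21 log units; within the scatter), stays within the scatter and shows no such clear loss. Nothing available explains the step. Still open, going by these compounds, is how an unsubstituted phenyl, an amine or a carboxylic acid at this position would compare with 3-chlorophenyl.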